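The source may hold more compounds than are shown below. What is called first, only, known or untested is meant among the compounds shown, and "the series" means these compounds.

Series notes, a functional assay on MIA PaCa-2 cells (Homo sapiens) for inhibition, read by MTT assay, with a stated time of 7 days; on this read-out lower numbers stand for stronger inhibition and higher numbers for weaker inhibition.

Measured so far:
compound 1 `CCC(CC)S(=O)(=O)c1ccc(S(=O)(=O)N2CCC[C@@H](C(=O)N3CCC(F)(F)CC3)C2)cc1`: 13 nM
compound 2 `CCN(CC)S(=O)(=O)c1ccc(S(=O)(=O)N2CCC[C@@H](C(=O)NC3COC3)C2)cc1`: 2340 nM
compound 3 `CCN(CC)C(=O)c1ccc(S(=O)(=O)N2CCC[C@@H](C(=O)N3CCC(F)(F)CC3)C2)cc1`: 70 nM

Compound 2 stands at the highest number of the three; the nearest is compound 3 and the furthest compound 1, both gaps well beyond the scatter. Among the measured compounds shown here, the only one-place step available, a 5.4-fold higher number from compound 1 to compound 3 (0.73 log units; beyond the scatter), concerns the aromatic end and leaves the amide end untouched, so it does not bear directly on the change now considered. Compound 4 `CCN(CC)S(=O)(=O)c1ccc(S(=O)(=O)N2CCC[C@@H](C(=O)N3CCS(=O)(=O)CC3)C2)cc1` differs from compound 2 at the carbonyl carbon: 1,1-dioxothiomorpholin-4-yl in place of (oxetan-3-yl)amino on a carbonyl carbon. For the measured compounds named here, what bears on this is that compound 1 and compound 3, the two whose carbonyl carries a ring rather than (oxetan-3-yl)amino, give far lower numbers than compound 2; no measured pair isolates that exchange on an otherwise identical core, so the size can only be read from those values, and compound 4 keeps the aryl end of compound 2, which has not been measured with any ring on the carbonyl. A large step downward in this assay is expected, about a 16-fold lower number from compound 2 to compound 4 (1.19 log units; beyond the scatter), though not necessarily reaching the level of compound 1. Compound 4 is estimated at 150 nM, range 30 nM to 800 nM.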

Compound 4, half-maximal inhibitory concentration: 900 nM
For compound 4 the middle estimate is 6.0-fold (0.78 log units) below the measured one, outside the stated range (above it).
By their numbers in this assay, from the lowest: compound 1; then compound 3; then compound 4; then compound 2.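

In this assay, the position on a carbonyl carbon whose other neighbour is a saturated ring carbon now has its first one-place reading: 1,1-dioxothiomorpholin-4-yl in place of (oxetan-3-yl)amino gives a 2.6-fold lower number from compound 2 to compound 4 (0.41 log units; beyond the scatter). The position therefore responds to this exchange, but the step is modest, and a six-membered non-aromatic ring on the carbonyl is not enough on its own to give a low number, as compound 4 still reads 900 nM. No measured property accompanies this step, so the data offer no account of its direction or size.

The compounds shown leave open how far the aryl end and the group on the carbonyl each contribute to the lower numbers of compound 1 and compound 3, since both differ from compound 4 in more than one place. Also open, on these data alone, is where a dimethylamino group, or a hydroxyl group giving the carboxylic acid, would fall on the same carbonyl carbon relative to (oxetan-3-yl)amino and 1,1-dioxothiomorpholin-4-yl.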